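A few compounds are considered here, and "the series" means these few. Any claim that something is new, unique, unknown or untested is made for them only; others in the source may bear on it.

Among the three compounds measured so far in a physicochemical assay for lipophilicity, measured as octanol-water partition (on this read-out higher numbers stand for higher lipophilicity and lower numbers for lower lipophilicity), compound 1 `O=C(COc1cccc2ccccc12)N/N=C/c1ccccc1Br` stands highest: compound 1 gives 4.81. Compound 2 `C/C(=N\NC(=O)COc1cccc2ccccc12)c1ccc(O)cc1O` gives 4.31, and compound 3 `C/C(=N\NC(=O)COc1cccc2ccccc12)c1ccc(Cl)cc1` gives 4.17, so compound 1 lies beyond the scatter above both. For the measured compounds named here, the only step between measured compounds that differ in one place is a number 0.14 log units lower from compound 2 to compound 3 (within the scatter), where a 4-chlorophenyl replaces a 2,4-dihydroxyphenyl on a carbon with a double bond to nitrogen; that step stays within the scatter.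

Compound 4 `COc1ccc(/C=N/NC(=O)COc2cccc3ccccc23)cc1` is not yet measured. Against compound 1 it differs in one place: 4-methoxyphenyl in place of 2-bromophenyl on a carbon with a double bond to nitrogen. Going by the values given here, the step from compound 2 to compound 3 touches the same position on the shared core but exchanges other groups, so it gives only a loose hint, and no measured pair swaps a 2-bromophenyl for a 4-methoxyphenyl. The expectation is nonetheless that compound 4 comes in lower than compound 1 in this assay, by a step of about a number 0.86 log units lower from compound 1 to compound 4 (beyond the scatter), beyond the scatter. Compound 4 is therefore estimated at 3.95, within a range from 3.55 to 4.35.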

Compound 4, partition coefficient: 3.77
Beside the measured number, compound 4's estimate is 0.18 log units above it; the measured number falls inside the stated range.
By their numbers in this assay, from the lowest: compound 4; then compounds 3 and 2 (each within the scatter of the next); then compound 1.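

In this assay, for the compounds shown here, the change from 2-bromophenyl to 4-methoxyphenyl on a carbon with a double bond to nitrogen gives a number 1.04 log units lower from compound 1 to compound 4 (beyond the scatter), the first step at this position that clearly exceeds the scatter. The earlier step at this position, a number 0.14 log units lower from compound 2 to compound 3 (within the scatter), stayed within the scatter, so the read-out does not stay flat for every exchange made here, although that earlier pair has a different set of groups and cannot be compared directly with this one. The change itself replaces a ring carrying bromine with a ring carrying methoxy, adding one heavy atom and one hydrogen-bond acceptor, but no measurement here accounts for the size of the step.

On these data alone, both the substituent and its place on the phenyl ring change in this single step, so the share of each remains open; a 4-bromophenyl or a 2-methoxyphenyl group at the same place would help separate the two. Also open, as far as these compounds go, is how the number would respond to a group of a different kind on that ring, such as an amine or a carboxylic acid.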